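Swapping the aryl group at the thioether-bearing carbon

A few compounds are considered here, and "the series" means these few. Any claim that something is new, unique, unknown or untested is made for them only; others in the source may bear on it.

Compound 1 `Cc1ccccc1-n1nc(C)c2c1NC(=O)[C@H](C)S[C@@H]2c1ccc(Oc2ccccc2)cc1`: 1300 nM
Compound 2 `Cc1ccccc1-n1nc(C)c2c1NC(=O)[C@H](C)S[C@@H]2c1ccc(Oc2ccccc2C(=O)O)cc1`: "not active" (no number reported)
Compound 3 `COC(=O)c1cccc(-c2ccc([C@H]3S[C@@H](C)C(=O)Nc4c3c(C)nn4-c3ccccc3C)cc2)c1`: "not active" (no number reported)

Three compounds share one core and differ only in the aryl group attached to the carbon that also carries the sulfur. In an assay on isolated protein for agonist activity at Bile acid receptor (Homo sapiens), read by AlphaScreen, with a stated time of 30 min (a lower number here means that less compound is needed, a higher number that more compound is needed for the effect), compound 1 gives 1300 nM. Compound 2 adds a carboxylic acid to the phenoxy group of compound 1; in this assay compound 2 gives "not active" (no number reported), so no number was reported for it. Compound 3, carrying a 3-(methoxycarbonyl)phenyl group instead of a phenoxy group, likewise gives "not active" (no number reported) in this assay, again with no number. Among the measured compounds shown here, compound 3 therefore stands without a measurable value, and the only compound in this set with a number is compound 1.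

Compound 4 `COc1ccc(Oc2ccc([C@H]3S[C@@H](C)C(=O)Nc4c3c(C)nn4-c3ccccc3C)cc2)cc1` is not yet measured. The change from compound 3 to compound 4 is 4-methoxyphenoxy in place of 3-(methoxycarbonyl)phenyl on an aromatic carbon. The group that enters resembles the phenoxy group of compound 1 with an added methoxy, whereas the acid of compound 2 is absent. The expectation in this assay is therefore that compound 4 regains an activity near that of compound 1, though the inactivity of compound 2 shows that substitution on the phenoxy ring can remove activity entirely. Compound 4 is estimated at 1500 nM, with a range from 400 nM to 6000 nM.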

Compound 4, half-maximal effective concentration: 2200 nM
Beside the measured number, compound 4's estimate is 1.5-fold (0.17 log units) below it; measured number inside the range.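

In this assay, the added methoxy on the phenoxy ring gives a 1.7-fold higher number from compound 1 to compound 4 (0.23 log units; within the scatter) and so leaves compound 1 and compound 4 indistinguishable, which shows that the phenoxy ring can carry this added group and keep a measurable value. Compound 3, with its 3-(methoxycarbonyl)phenyl group, gives "not active" (no number reported) while compound 4, with 4-methoxyphenoxy at the same place, gives 2200 nM in this comparison, so the choice of group here separates a readable value from none, and compound 2 shows that a substituted phenoxy ring does not always keep activity. No measurement shown here explains these differences.

The compounds shown cannot separate the effect of the carboxylic acid in compound 2 from the effect of where it sits, and a 4-carboxyphenoxy group would be needed to tell those apart. Going by these compounds, it also remains open whether an amine or a longer chain such as ethoxy on the phenoxy ring would keep the value near that of compound 1 and compound 4, or would remove it as the acid of compound 2 did.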